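Fluoro to chloro on compound 2

The source may report more compounds than this note shows. Statements on the series, on what has been measured and on what is new or still open speak of the compounds shown alone.

For the measured compounds named here, in a physicochemical assay for permeability, using PAMPA (a higher number here means that the compound crosses the layer faster, a lower number that the compound crosses the layer more slowly), compound 2 (`C[C@@H](Oc1cc2oc(=O)n(CCC(=O)O)c2cc1Cl)c1ccc(F)cn1`) gives 31 nm/s as the only true number so far. Compound 1 (`COCCOc1cc2oc(=O)n(CCC(=O)O)c2cc1Cl`) sits at < 3 nm/s as a limit of the assay. Compound 3 (`COc1cc2oc(=O)n(CCC(=O)O)c2cc1Cl`) sits at < 3 nm/s as a limit too.

Going by the values given here, compound 4 (`C[C@@H](Oc1cc2oc(=O)n(CCC(=O)O)c2cc1Cl)c1ccc(Cl)cn1`) carries chloro in place of fluoro on an aromatic carbon as its only change.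

Among the compounds with values here, the sole measured step is a step that the two limits leave unreadable from compound 1 to compound 3 and it concerns a different place, so it gives no size for this change. The remaining evidence is the limit of < 3 nm/s in this assay, at which 2 of the 3 values shown sit, and it does not touch the halogen.

The expectation therefore stays with compound 2 at 31 nm/s and no step beyond the scatter is expected in this assay in either direction. The estimated step is a 1.1-fold higher number from compound 2 to compound 4 (0.05 log units; within the scatter) and it is expected to be small. Compound 4 is estimated at 35 nm/s within an expected range of 14 nm/s to 85 nm/s for now.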

Compound 4, apparent permeability: 60 nm/s
Estimate against measurement, compound 4: 1.7-fold (0.23 log units) below; measured number inside the range.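

At this position the change now has a size, since both compounds give true numbers in this assay, unlike the step between the two limited compounds. Going from 5-fluoropyridin-2-yl to 5-chloropyridin-2-yl gives a 1.9-fold higher number from compound 2 to compound 4 (0.29 log units; within the scatter), so the two halogens are not told apart here. No evidence shown bears on this halogen change.

Open, going by these compounds, is whether a nitrile, a trifluoromethyl or an amine on this same aromatic carbon would read like the two halogens. Also open, on these data alone, is how plain hydrogen there would read.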